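Ester Change on a Shared Core and Its Cytotoxicity Read-Out

The source may hold more compounds than are shown below. What is called first, only, known or untested is meant among the compounds shown, and "the series" means these compounds.

Measured compounds:
- compound 1 `O=c1c(CCO)c(-c2ccccc2Cl)c2cc(Cl)ccc2n1-c1c(F)cccc1F`; in an ADME assay on HepG2 2.2.15 cells (Homo sapiens) for cytotoxicity (on this read-out lower numbers stand for higher toxicity in this test and higher numbers for lower toxicity in this test), compound 1 gives a limit, > 2300000 nM.
- compound 2 `O=C(OCCc1c(-c2ccccc2Cl)c2cc(Cl)ccc2[nH]c1=O)C1CCCCC1`; compound 2 gives 38000 nM.
- compound 3 `O=C(OCCc1c(-c2ccccc2Cl)c2cc(Cl)ccc2[nH]c1=O)c1cccs1`; compound 3 gives a limit, > 1700000 nM.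

Among the compounds with values here, compound 2 is the only compound with a plain number; the other two stand at limits. Compound 4 `O=C(/C=C/c1cccnc1)OCCc1c(-c2ccccc2Cl)c2cc(Cl)ccc2[nH]c1=O` is not yet measured and differs from compound 2 by 2-(pyridin-3-yl)ethenyl in place of cyclohexyl on a carbonyl carbon. Within the data shown here, one measured step bears on this: an at least 44-fold higher number from compound 2 to compound 3 (1.65 log units; beyond the scatter), where an aromatic group also replaced the cyclohexyl group. A higher number is therefore expected for compound 4, with the step of a 13-fold higher number from compound 2 to compound 4 (1.12 log units; beyond the scatter), and a limit such as the limit of > 1700000 nM in this assay, at which 1 of the 3 values shown sits, would not be surprising. Compound 4 is estimated at 500000 nM, between 60000 nM and 2000000 nM.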

Compound 4, half-maximal cytotoxic concentration: 39000 nM
For compound 4 the middle estimate is 13-fold (1.11 log units) above the measured one, and the stated range ends above it.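

An aromatic ring in the group on this carbonyl carbon does not by itself lift the number in this assay and the step is a 1.0-fold higher number from compound 2 to compound 4 (0.01 log units; within the scatter) so 2-(pyridin-3-yl)ethenyl and cyclohexyl read alike. Against thiophen-2-yl the change gives an at least 43-fold lower number from compound 3 to compound 4 (1.63 log units; beyond the scatter) and this step is read from a limit for compound 3, not from a plain number. Nothing shown here accounts for this difference. Open, from the compounds shown here alone, is whether the ethenyl link or the pyridine ring matters more, and how a plain phenyl group or a 2-aminoethyl chain would read at this place.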